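This account rests on a few compounds, and the source may have more. Where it says the series, first, only, none or still open, it means among the compounds named here.

Measured so far in an ADME assay on HEL cells (Homo sapiens) for cytotoxicity, read by microscopy, with a stated time of 6 days; on this read-out higher numbers stand for lower toxicity in this test and lower numbers for higher toxicity in this test:

- compound 1 `CCCCCCCCNc1cncc(C(=O)NCc2ccccc2)n1` gives the limit > 100000 nM.
- compound 2 `CCCCNc1cncc(C(=O)NCc2ccccc2)n1` gives the limit > 100000 nM.
- compound 3 `CCCCCCCNc1nccnc1C(=O)NCc1ccccc1` gives 100000 nM.

In this assay compound 2 stands only at a limit, not at a number. Within the data shown here, the one step that connects it to another measured compound, a step that the two limits leave unreadable from compound 1 to compound 2, is therefore unreadable in size, since both ends sit at a limit; all that can be said is that the two values fall at the limit of > 100000 nM in this assay, at which 2 of the 3 values shown sit. Among the measured compounds shown here, compound 3, the only compound with an actual number, reads at the same concentration as that limit, so none of the three measured compounds shows any toxicity within the tested range.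

The unmeasured compound 4 `CCCCCCCNc1cncc(C(=O)NCc2ccccc2)n1` differs from compound 2 by propyl in place of hydrogen on a saturated chain carbon, four bonds along the chain from a nitrogen on an aromatic ring. For the measured compounds named here, no measured step covers this change in this direction; the only related change, the removal of a chain from compound 1 to compound 2, was unreadable. With compound 1 and compound 2 both at the limit of > 100000 nM in this assay, at which 2 of the 3 values shown sit, compound 4 is expected to remain at the limit, a step of a number no higher from compound 2 to compound 4 (the limit leaves the size open) that means no change beyond the scatter. Compound 4 is thus estimated at 100000 nM, between 50000 nM and 200000 nM.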

Compound 4, minimum cytotoxic concentration: > 100000 nM
Compound 4: no number, only a limit (the forecaster's own chance of this, stated with the estimate: 85%); the middle value sits exactly at the limit.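

The steps linking compound 4 to compound 2 and to compound 1 cannot be read, as all three compounds stand at a limit in this assay: the limit of > 100000 nM in this assay, at which 3 of the 4 values shown sit.

The compounds shown leave open whether the length of the chain on the shared core changes the minimum cytotoxic concentration at all.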